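The compounds below may be only part of what the source reports. "The series", "measured", "known", "first", "only" and "open" are said of these compounds alone.

Working notes on a small set sharing one core. Compound 1 `O=C(NCc1ccc(F)cc1)c1nc(NCCO)c2cccnc2c1O` carries no result in a functional assay on HCT-116 cells (Homo sapiens) for cytotoxicity, read by MTT assay, with a stated time of 72 h; a lower number here means a stronger inhibitor, a higher number a weaker inhibitor: "not determined" (no result reported). For compound 2 `CC(C)(C)OC(=O)N1CCN(c2c(C(=O)NCc3ccc(F)cc3)nc(Br)c3cccnc23)CC1` the read-out in this assay is only a limit, > 10000 nM. For compound 3 `O=C(NCc1ccc(F)cc1)c1nc(Br)c2cccnc2c1NCc1ccc(F)cc1` the read-out in this assay is likewise only a limit, > 20000 nM. Among the compounds with values here, compound 3 thus stands without a single number; one other entry is also a limit and one has no result, so no measured step within the set exists. Compound 4 `Cc1ccc(S(=O)(=O)Oc2c(C(=O)NCc3ccc(F)cc3)nc(Br)c3cccnc23)cc1` is not yet measured and differs from compound 3 by ((4-methylphenyl)sulfonyl)oxy in place of (4-fluorobenzyl)amino on an aromatic carbon. No step beyond the usual scatter of this assay is expected in either direction. Compound 4 is expected near 15000 nM, within 3000 nM to 60000 nM, meaning an expected step of an at least 1.3-fold lower number from compound 3 to compound 4 (0.12 log units; that floor lies within the scatter).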

Compound 4, half-maximal inhibitory concentration: > 20000 nM
Compound 4: a limit, no number; the forecaster's own chance of this, stated with the estimate: 65%; middle value at least 1.3-fold (0.12 log units) from the limit.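

In this assay, compound 3 and compound 4 both give only limits, so no step between them can be read: the limit of > 20000 nM in this assay, at which 2 of the 4 values shown sit.

The compounds shown leave open whether ((4-methylphenyl)sulfonyl)oxy and (4-fluorobenzyl)amino differ in effect, as the series has no single number.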